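A few compounds are considered here, and "the series" means these few. Any claim that something is new, unique, unknown or untested is made for them only; others in the source may bear on it.

Measured so far:
Compound 1, `O=C1Nc2ccc(C(=O)c3ccco3)cc2/C1=C/c1cc(Cl)c(O)c(Br)c1`, gives 62% in an assay on HeLa cells for inhibition of Kinesin-like protein KIF15 (Homo sapiens), read by microscopy, with stated times of 2 s and 20 s, tested at 750 nM; a lower number here means less inhibition, a higher number more inhibition at the concentration tested (going by the name of the read-out).
Compound 2, `O=C1Nc2ccc(C(=O)c3ccco3)cc2/C1=C/c1ccc(Br)c(O)c1`, gives -5.6% in this assay.

Among the measured compounds shown here, compound 2 stands lowest of the two numbers; the only comparison is with compound 1, and the step of a number 67.6 percentage points lower from compound 1 to compound 2 (beyond the scatter) shows how far apart they lie. Compound 3, `COc1ccc(/C=C2\C(=O)Nc3ccc(C(=O)c4ccco4)cc32)cc1Br`, has not been measured. It differs from compound 2 by 3-bromo-4-methoxyphenyl in place of 4-bromo-3-hydroxyphenyl on a double-bonded chain carbon bound to a double-bonded ring carbon. For the measured compounds named here, the one measured step, a number 67.6 percentage points lower from compound 1 to compound 2 (beyond the scatter), also changed the group at this same place and was large, so swapping this group can move the read-out a great deal; but that step went from a group with two halogens and a hydroxyl to one with one halogen and a hydroxyl, while compound 3 keeps one halogen and carries a methoxy instead of the hydroxyl. That leaves the direction of the step uncertain, and the expected step of a number 17.6 percentage points higher from compound 2 to compound 3 (beyond the scatter) is a modest rise with a wide range. Compound 3 is estimated at 12%, between -15% and 45%.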

Compound 3, a percentage reported as inhibition, at one concentration (the size of the read-out at that concentration, not a potency): 2.3%
Compound 3: the middle estimate sits 9.7 percentage points above what was measured; the range from low to high includes it.
By their numbers in this assay, from the lowest: compounds 2 and 3 (each within the scatter of the next); then compound 1.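

In this assay, putting 3-bromo-4-methoxyphenyl in place of 4-bromo-3-hydroxyphenyl gives a number 7.9 percentage points higher from compound 2 to compound 3 (within the scatter), so a methoxy instead of a hydroxyl and a changed arrangement of the groups on the ring leave the two compounds indistinguishable at this place. The comparison with the two-halogen group gives a number 59.7 percentage points lower from compound 1 to compound 3 (beyond the scatter), so among these three compounds, only the group of compound 1, which carries chlorine, bromine and a hydroxyl, gives a high reading. Nothing measured here gives a reason for these numbers. Going by these compounds, it remains open whether the high reading of compound 1 depends on the chlorine, the hydroxyl or the two together. On these data alone, how an amine or a carboxylic acid in place of the hydroxyl would read on this ring is also open.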